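Swapping a benzoyl substituent on an indole hydroxamic acid

The source may report more compounds than this note shows. Statements on the series, on what has been measured and on what is new or still open speak of the compounds shown alone.

Measured so far:
- compound 1, `COc1ccc(C(=O)c2ccc3c(ccn3Cc3ccc(C(=O)NO)cc3)c2)cc1OC`: 756 nM
- compound 2, `COc1cc(C(=O)c2ccc3c(ccn3S(=O)(=O)c3cccc(/C=C/C(=O)NO)c3)c2)cc(OC)c1OC`: 1260 nM
- compound 3, `COc1cc(C(=O)c2ccc3c(ccn3Cc3ccc(C(=O)NO)cc3)c2)cc(OC)c1OC`: "not determined" (no result reported)

In an assay on isolated protein for inhibition of histone deacetylase 8 (Homo sapiens) (on this read-out higher numbers stand for weaker inhibition and lower numbers for stronger inhibition), compound 1 gives 756 nM, the lowest of the two numbers, though compound 2 at 1260 nM lies within the scatter of it. Compound 3 carries the same core as compound 1 with an extra methoxy group and has no reported value.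

Compound 4, `O=C(NO)c1ccc(Cn2ccc3cc(C(=O)c4ccc(Cl)cc4)ccc32)cc1`, differs from compound 1 by 4-chlorophenyl in place of 3,4-dimethoxyphenyl on a carbonyl carbon. Within the data shown here, no pair of measured compounds shows the effect of this change, so the expectation rests on compound 1 alone. A step of no more than the scatter, in either direction, is expected as a 1.1-fold lower number from compound 1 to compound 4 (0.03 log units; within the scatter). Compound 4 is therefore estimated at 700 nM, between 250 nM and 2000 nM.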

Compound 4, half-maximal inhibitory concentration: 1060 nM
The estimate for compound 4 lay 1.5-fold (0.18 log units) below the measured number; the measured number falls inside the stated range.
By their numbers in this assay, from the lowest: compounds 1, 4 and 2 (each within the scatter of the next).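

In this assay, placing 4-chlorophenyl in place of 3,4-dimethoxyphenyl on a carbonyl carbon gives a 1.4-fold higher number from compound 1 to compound 4 (0.15 log units; within the scatter). At this position, then, a ring with hydrogen-bond acceptors can give way to a smaller one with none and a chlorine, without a step beyond the scatter. Nothing available explains this result.

Still open, from the compounds shown here alone, is whether an amine or a carboxylic acid on this ring would give a larger step. A longer chain in place of the ring is equally untested by these compounds.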